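Sulfonyl exchange from compound 2 to compound 3

The source may report more compounds than this note shows. Statements on the series, on what has been measured and on what is new or still open speak of the compounds shown alone.

Among the measured compounds shown here, in a physicochemical assay for solubility, in phosphate buffer, with a stated time of 24 h, at pH 7.4 (on this read-out higher numbers stand for higher solubility and lower numbers for lower solubility), compound 2 (`COc1ccc(-c2ccc(OCc3cc(C(=O)NS(=O)(=O)c4ccccc4)oc3C)cc2)nc1`) gives 30 ug/mL, the lower of the two numbers so far. Compound 1 (`COc1ccc(-c2ccc(OCc3cc(C(=O)NS(=O)(=O)c4c(C)noc4C)oc3C)cc2)c(C)c1`) gives 200 ug/mL, a gap beyond the usual scatter. Compound 3 (`COc1ccc(-c2ccc(OCc3cc(C(=O)NS(=O)(=O)c4c(C)noc4C)oc3C)cc2)nc1`) is not yet measured. It differs from compound 2 by one change on the sulfonyl sulfur: 3,5-dimethyl-1,2-oxazol-4-yl in place of phenyl on a sulfonyl sulfur. For the measured compounds named here, the incoming 3,5-dimethyl-1,2-oxazol-4-yl is also present in compound 1, but that compound differs from compound 2 elsewhere too, so no measured step isolates this change. The expectation therefore rests on two values only, and it is uncertain. An upward move beyond the scatter is expected, with the estimated step of a 3.3-fold higher number from compound 2 to compound 3 (0.52 log units; beyond the scatter). The estimated value for compound 3 is 100 ug/mL, with an expected range of 35 ug/mL to 300 ug/mL.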

Compound 3, solubility: 90 ug/mL
Estimate against measurement, compound 3: 1.1-fold (0.05 log units) above; low and high end bracket the measured number.
By their numbers in this assay, from the lowest: compound 2; then compound 3; then compound 1.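

In this assay the change from phenyl to 3,5-dimethyl-1,2-oxazol-4-yl on a sulfonyl sulfur now has a measured step of its own (a 3.0-fold higher number from compound 2 to compound 3 (0.48 log units; beyond the scatter)). Compound 3 also isolates a second single change, 5-methoxypyridin-2-yl in place of 4-methoxy-2-methylphenyl on an aromatic carbon (a 2.2-fold lower number from compound 1 to compound 3 (0.35 log units; beyond the scatter)), so the gap between compound 1 and compound 2 now resolves into two single-place steps, both modest and both beyond the scatter. Nothing at hand gives a reason for either step.

From the compounds shown here alone, each step is seen only once, so whether either holds with the other aromatic group in place remains open. Also open, going by these compounds, is how this assay would read with a methyl group, or a phenyl carrying a carboxylic acid, on the sulfonyl sulfur.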